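The source may report more compounds than this note shows. Statements on the series, on what has been measured and on what is new or still open speak of the compounds shown alone.

Measured compounds:
compound 1, `CCn1c(CN2CCN(C(=O)C3CC3)CC2)nc2ccccc21`, 20.8%
compound 2, `Cc1cccc(Cn2c(CN3CCN(C(=O)CC(C)C)CC3)nc3ccccc32)c1`, 71.4%
compound 3, `Cc1cccc(Cn2c(CN3CCN(C(=O)c4ccc(C#N)cc4)CC3)nc3ccccc32)c1`, 20.8%

Of the compounds shown here, three sharing one core have been tested in an assay on isolated protein for inhibition of aldehyde dehydrogenase 1A1 (Homo sapiens), read by spectrophotometry, tested at 10 uM; a lower number here means less inhibition, a higher number more inhibition at the concentration tested (going by the name of the read-out). Compound 1 gives 20.8%, level with compound 3 at the digits shown and, together with it, the lowest of the three numbers; the one compound well apart from it is compound 2, whose value stands far higher. Going by the values given here, the only step between two compounds that differ in one place is a number 50.6 percentage points lower from compound 2 to compound 3 (beyond the scatter); it concerns the group on the carbonyl carbon and leaves the group on the chain carbon bound to the aromatic nitrogen untouched.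

The unmeasured compound 4, `O=C(C1CC1)N1CCN(Cc2nc3ccccc3n2Cc2ccccc2)CC1`, differs from compound 1 as follows: phenyl in place of methyl on a saturated chain carbon bound to an aromatic nitrogen. Among the compounds with values here, no measured pair isolates this change, so the step of compound 2 to compound 3 bears on it only indirectly: it shows that the shared core with a benzyl-type group on that nitrogen can give either a high or a low number depending on the carbonyl substituent. Compound 4 keeps the cyclopropyl carbonyl of compound 1, and compound 1 gives 20.8%. The expectation for compound 4 is therefore cautious: a step of a number 11.2 percentage points higher from compound 1 to compound 4 (beyond the scatter), which may well fall within the scatter. Compound 4 is estimated at 32%, with a range from 8% to 62%.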

Compound 4, a percentage reported as inhibition, at one concentration (the size of the read-out at that concentration, not a potency): 23.9%
Beside the measured number, compound 4's estimate is 8.1 percentage points above it, within the range that was stated.
By their numbers in this assay, from the lowest: compounds 1, 3 and 4 (each within the scatter of the next); then compound 2.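

In this assay, going by these compounds alone, the pair of compound 1 and compound 4 isolates the group on the saturated chain carbon bound to the aromatic nitrogen for the first time, and phenyl in place of methyl there gives a number 3.1 percentage points higher from compound 1 to compound 4 (within the scatter). With the cyclopropyl carbonyl kept, ethyl and benzyl at this place therefore cannot be told apart by this read-out, although the added phenyl brings one six-membered aromatic ring of carbon only. The one step beyond the scatter shown for this series remains the one on the carbonyl carbon, a number 50.6 percentage points lower from compound 2 to compound 3 (beyond the scatter), while no information at hand explains why the ethyl to benzyl change leaves the two numbers so close.

On these data alone, it remains open whether ethyl and benzyl would also stand within the scatter of each other with isobutyl or 4-cyanophenyl on the carbonyl carbon, so the finding is tied to the cyclopropyl carbonyl alone. Also open, as far as these compounds go, is what this assay would show for other groups at the same place, such as a longer chain like n-butyl, a chain ending in an amine or a carboxylic acid, or a bare hydrogen in place of ethyl.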